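The source may report more compounds than this note shows. Statements on the series, on what has been measured and on what is new or still open speak of the compounds shown alone.

Of the compounds shown here, three sharing one core have been tested in an ADME assay on HeLa cells (Homo sapiens) for cytotoxicity, read by MTT assay, with a stated time of 72 h; on this read-out higher numbers stand for weaker inhibition of growth and lower numbers for stronger inhibition of growth. Compound 1 `O=C(/C=C\c1ccccc1)N1N=C(c2ccncc2)OC1c1c[nH]c2ccccc12` reaches only the limit of the assay, > 30 ug/mL. Compound 2 `O=C(/C=C\c1ccccc1O)N1N=C(c2ccncc2)OC1c1c[nH]c2ccccc12` carries a hydroxy in place of hydrogen on an aromatic carbon and is the only one of the three to give a number in this assay, 26.8 ug/mL. Compound 3 `O=C(/C=C\c1ccccc1[N+](=O)[O-])N1N=C(c2ccncc2)OC1c1c[nH]c2ccccc12` carries a nitro in place of hydrogen on an aromatic carbon and likewise sits at the limit of this assay, > 30 ug/mL. Thus compound 2 stands as the sole numbered point among the three, the other two resting at the limit (the limit of > 30 ug/mL in this assay, at which 2 of the 3 values shown sit).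

Compound 4 `O=C(/C=C\c1ccc([N+](=O)[O-])cc1)N1N=C(c2ccncc2)OC1c1c[nH]c2ccccc12` is the next candidate; it differs from compound 2 by 4-nitrophenyl in place of 2-hydroxyphenyl on a double-bonded chain carbon bound to a double-bonded chain carbon. The step most related to this change is an at least 1.1-fold higher number from compound 2 to compound 3 (0.04 log units; that floor lies within the scatter), and the steps of an at least 1.1-fold lower number from compound 1 to compound 2 (0.04 log units; that floor lies within the scatter) and a step that the two limits leave unreadable from compound 1 to compound 3 add little beyond showing that none of the three compounds moves far from the limit. On this basis no step beyond the scatter in this assay is expected from compound 2 to compound 4; the estimated step is a 1.1-fold higher number from compound 2 to compound 4 (0.05 log units; within the scatter), with a fair chance that the assay again reports only its limit. Compound 4 is therefore expected to give about 30 ug/mL, within a range of 15 ug/mL to 60 ug/mL.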

Compound 4, concentration for 50% growth inhibition: > 30 ug/mL
Compound 4: no number, only a limit; the forecaster's own chance of this, stated with the estimate: 60%; the middle value sits exactly at the limit.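

Exchanging 2-hydroxyphenyl for 4-nitrophenyl on a double-bonded chain carbon bound to a double-bonded chain carbon appears as an at least 1.1-fold higher number from compound 2 to compound 4 (0.04 log units; that floor lies within the scatter), so this change yields only a floor and no readable shift in growth inhibition. What the result adds is a second nitro-bearing compound: compound 4 joins compound 3 in giving no number in this assay, and the steps from compound 3 to compound 4 and from compound 1 to compound 4 cannot be read, with a limit at both ends of each. Going by these compounds alone, compound 2 remains the only compound here with a number, and the other compounds share one boundary: the limit of > 30 ug/mL in this assay, at which 3 of the 4 values shown sit.

As far as these compounds go, how far growth inhibition would move with an amine or a carboxylic acid in place of the hydroxy or the nitro stays open, as does whether any group at this position can carry the series clearly away from the limit. The limits also leave open how compound 1, compound 3 and compound 4 rank among themselves, and whether the hydroxy of compound 2 makes any real difference at all.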